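This account rests on a few compounds, and the source may have more. Where it says the series, first, only, none or still open, it means among the compounds named here.

Compound 1 `COc1cc(-c2nn(-c3cccc(NC(=O)Nc4ccc(Cl)c(Cl)c4)c3)cc2-c2ccncc2)ccc1Cl` carries a urea that joins a 3,4-dichlorophenyl group to the shared core. In a functional assay on HOP-62 cells (Homo sapiens) for inhibition, read by sulforhodamine B assay, with a stated time of 48 h (a lower number here means that less compound is tolerated, a higher number that more compound is tolerated), compound 1 gives only a limit, > 50000 nM, so its position is known just as the limit (the limit of > 50000 nM in this assay, at which 1 of the 3 values shown sits). Compound 2 `O=C(Nc1cccc(-n2cc(-c3ccncc3)c(-c3ccc(Cl)c(O)c3)n2)c1)Nc1ccc(Cl)c(Cl)c1` differs from compound 1 by hydrogen in place of methyl on an oxygen on an aromatic ring, and the step from compound 1 to compound 2 is a step that the two limits leave unreadable from compound 1 to compound 2. Compound 2 likewise gives only a limit in this assay, > 32500 nM, which is the limit (the limit of > 32500 nM in this assay, at which 1 of the 3 values shown sits). Compound 3 `O=C(Nc1cccc(-n2cc(-c3ccncc3)c(-c3ccc(Cl)c(O)c3)n2)c1)Nc1cc(C(F)(F)F)cc(C(F)(F)F)c1`, whose urea bears trifluoromethyl rather than chloro, gives 4070 nM in this assay. Compound 4 `COc1cc(-c2nn(-c3cccc(NC(=O)Nc4ccc(Cl)c(C(F)(F)F)c4)c3)cc2-c2ccncc2)ccc1Cl` is compound 1 with trifluoromethyl in place of chloro on an aromatic carbon. Going by the values given here, no measured step isolates this change; the only hint is that compound 3 shows a number where compound 2 shows a limit. The step from compound 1 to compound 4 is expected to be an at least 1.2-fold lower number from compound 1 to compound 4 (0.09 log units; that floor lies within the scatter), with another limit quite possible. For compound 4 the estimate in this assay is 40000 nM, with a range from 8000 nM to 100000 nM.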

Compound 4, concentration lethal to 50% of the cells: 31000 nM
Estimate against measurement, compound 4: 1.3-fold (0.11 log units) above; low and high end bracket the measured number.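

Turning 3,4-dichlorophenyl into 4-chloro-3-(trifluoromethyl)phenyl gives the first measured number for this change, as in this assay compound 4 gives 31000 nM. The result is an at least 1.6-fold lower number from compound 1 to compound 4 (0.20 log units; that floor lies within the scatter), so the change is measured directly here, but the printed floor alone does not take it beyond the usual scatter, and the true step may be larger. The other end of the step is only a limit, not a number, for compound 1: the limit of > 50000 nM in this assay, at which 1 of the 4 values shown sits.

The compounds shown leave open how large the step really is, and whether trifluoromethyl in place of chloro at this position would act the same way on the hydroxyl-bearing compound 2. They also leave open what a nitrile or an amine on this same aromatic carbon would do to the number.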